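Drawn configuration and a cytotoxicity limit

This account rests on a few compounds, and the source may have more. Where it says the series, first, only, none or still open, it means among the compounds named here.

Values in a functional assay on HepG2 cells (Homo sapiens) for cytotoxicity, read by MTT assay (on this read-out lower numbers stand for stronger inhibition and higher numbers for weaker inhibition), follow, each one a limit of the assay.
- Compound 1 `CC1(C)CCc2c(C3CCc4ccc(O)cc4O3)ccc(O)c2O1` gives > 100000 nM as a limit
- Compound 2 `CC1(C)CCc2c([C@@H]3CCc4ccc(O)cc4O3)ccc(O)c2O1` gives > 100000 nM as a limit
- Compound 3 `CC1(C)C=Cc2c([C@H]3CCc4ccc(O)cc4O3)ccc(O)c2O1` gives > 100000 nM as a limit

Compound 3 has no position apart from the others, and the record shows (the limit of > 100000 nM in this assay, at which 3 of the 3 values shown sit). Compound 4 `CC1(C)C=Cc2c(C3CCc4ccc(O)cc4O3)ccc(O)c2O1` differs from compound 3 in a single respect: the two compounds have the same atoms and bonds; at least one stereo element is drawn with a configuration in one of them and without one in the other: 1 of 1 stereo elements differ; a stereocentre at a saturated ring carbon is drawn R in compound 3 and without a configuration in compound 4. The closest measured comparison is a step that the two limits leave unreadable from compound 1 to compound 2, resting on (the fact that one of compounds 1 and 2 is drawn with a defined configuration and the other without, at the place where they differ), and it offers no size to carry over, though neither compound leaves the limit. No step beyond the scatter is therefore expected in this assay, and the estimated step is a number no higher from compound 3 to compound 4 (the limit leaves the size open). For compound 4 the estimated value is 100000 nM, with an expected range from 50000 nM to 200000 nM, and it will most likely be reported as a limit again.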

Compound 4, half-maximal inhibitory concentration: 92800 nM
Estimate against measurement, compound 4: 1.1-fold (0.03 log units) above; the range from low to high includes it.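

Going by these compounds alone, compound 4, at 92800 nM in this assay, is the first compound here to give a number rather than a limit. Within the data shown here, this makes the stereocentre at a saturated ring carbon readable for the first time, as an at least 1.0-fold lower number from compound 3 to compound 4 (0.03 log units; that floor lies within the scatter), whereas the earlier step between compounds with and without a drawn configuration cannot be read. The only difference behind this step is: the fact that one of compounds 3 and 4 is drawn with a defined configuration and the other without, at the place where they differ

The compounds shown leave open how a drawn R and a drawn S compare on an otherwise identical structure. They also leave open whether an amine or a carboxylic acid on the shared core would give a value clear of the limit.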